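Chromone dithiazoles on IMR-32 cells: methyl in place of hydrogen

The source may report more compounds than this note shows. Statements on the series, on what has been measured and on what is new or still open speak of the compounds shown alone.

Measured so far:
compound 1 `O=c1c(C(=S)Nc2ccccc2)coc2ccccc12` — 95800 nM
compound 2 `O=c1c(C2N=C(c3ccccc3)SS2)coc2ccccc12` — 16500 nM
compound 3 `O=c1c(C2N=C(c3ccccc3)SS2)coc2cc(Cl)ccc12` — 95100 nM

In a functional assay on IMR-32 cells (Homo sapiens) for inhibition, read by sulforhodamine B assay, with a stated time of 48 h (a lower number here means a stronger inhibitor, a higher number a weaker inhibitor), compound 2 gives the lowest of the three numbers; compound 1 and compound 3 both stand higher by amounts beyond the scatter. Compound 4 `Cc1ccc2occ(C3N=C(c4ccccc4)SS3)c(=O)c2c1` differs from compound 2 by methyl in place of hydrogen on an aromatic carbon. For the measured compounds named here, the one step that bears on a substituent entering the shared core is a 5.8-fold higher number from compound 2 to compound 3 (0.76 log units; beyond the scatter), which moved in the weakening direction. A methyl is not a chloro, and the two sit at different places, so this is only a loose guide; compound 4 is expected to move in the same direction, to a lesser degree, as a 1.8-fold higher number from compound 2 to compound 4 (0.26 log units; within the scatter). The estimate for compound 4 in this assay is 30000 nM, with a range of 10000 nM to 90000 nM.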

Compound 4, half-maximal inhibitory concentration: 70700 nM
Beside the measured number, compound 4's estimate is 2.4-fold (0.37 log units) below it, within the range that was stated.
By their numbers in this assay, from the lowest: compound 2; then compounds 4, 3 and 1 (each within the scatter of the next).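

Within this assay, methyl in place of hydrogen on this aromatic carbon, meta to a fused ring and para to a fused ring, gives a 4.3-fold higher number from compound 2 to compound 4 (0.63 log units; beyond the scatter). The weakening is therefore not confined to chloro, which gave a 5.8-fold higher number from compound 2 to compound 3 (0.76 log units; beyond the scatter) at a different place on the shared core, and compound 2, with neither substituent, keeps the lowest number. No measurement at hand explains either step.

On these data alone, whether a methoxy group or an amine at the methyl's position would also raise the number remains open. So does whether any substituent on this carbon can lower it.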